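The source may hold more compounds than are shown below. What is called first, only, known or untested is meant among the compounds shown, and "the series" means these compounds.

In a functional assay on NIH3T3 cells (Mus musculus) (a lower number here means that less compound is needed, a higher number that more compound is needed for the effect), compound 1 `CCC/C=C/C=C/c1cc(C#N)ccc1COC(c1ccc(C#N)cc1)c1cncn1C` gives 16.7 nM and compound 2 `Cn1cncc1C(OCc1ccc(C#N)cc1C#Cc1ccc(C#N)cc1)c1ccc(C#N)cc1` gives 11.6 nM, with a 1.4-fold lower number from compound 1 to compound 2 (0.16 log units; within the scatter). Compound 3 `Cn1cncc1C(OCc1ccc(C#N)cc1-c1ccc(C#N)cc1)c1ccc(C#N)cc1` gives < 0.1 nM, which is a limit and not a number. It sits at the limit of < 0.1 nM in this assay, at which 1 of the 3 values shown sits. Putting 4-cyanophenyl at this place produced two large steps, an at least 160-fold lower number from compound 1 to compound 3 (2.22 log units; beyond the scatter) and an at least 110-fold lower number from compound 2 to compound 3 (2.06 log units; beyond the scatter). Compound 4 `Cn1cncc1C(OCc1ccc(C#N)cc1CCC(C)(C)C)c1ccc(C#N)cc1` carries 3,3-dimethylbutyl in place of 4-cyanophenyl on an aromatic carbon. Read in reverse, those two steps suggest that losing 4-cyanophenyl will bring a large move to a higher number in this assay, although neither earlier group is 3,3-dimethylbutyl. The expected change is an at least 60-fold higher number from compound 3 to compound 4 (1.77 log units; beyond the scatter). For compound 4 the estimated value is 6 nM, within an expected range of 0.6 nM to 40 nM.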

Compound 4, half-maximal effective concentration: 0.54 nM
Beside the measured number, compound 4's estimate is 11-fold (1.05 log units) above it, outside the stated range (below it).
By their numbers in this assay, from the lowest: compound 4; then compounds 2 and 1 (each within the scatter of the next). At a limit, below all of these: compound 3.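

Here 3,3-dimethylbutyl, which has no ring, still brings a 21-fold lower number from compound 2 to compound 4 (1.33 log units; beyond the scatter) and a 31-fold lower number from compound 1 to compound 4 (1.49 log units; beyond the scatter), so in this assay an aromatic ring at this position is not required for a low number. Replacing 4-cyanophenyl still gives an at least 5.4-fold higher number from compound 3 to compound 4 (0.73 log units; beyond the scatter). That step is only a bound, as the value of compound 3 is a limit: the limit of < 0.1 nM in this assay, at which 1 of the 4 values shown sits.

From the compounds shown here alone, it remains open whether a longer chain, or a chain ending in an amine, would keep the number of compound 4. Going by these compounds, whether a plain phenyl would match 4-cyanophenyl also remains open.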